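Bombesin receptor subtype-3 agonists: replacing tert-butyl with 4-chlorobenzyl

A few compounds are considered here, and "the series" means these few. Any claim that something is new, unique, unknown or untested is made for them only; others in the source may bear on it.

Measured compounds:
compound 1, `O=C(O)c1ccccc1-c1ccc(CCc2ncc(Cc3cccc(Cl)c3)[nH]2)cc1`, 31 nM
compound 2, `CC(C)(C)CCc1cnc(CCc2ccc(-c3ccccc3C(=O)O)cc2)[nH]1`, 6.2 nM
compound 3, `CC(C)(C)c1cnc(CCc2ccc(-c3ccccc3C(=O)O)cc2)[nH]1`, 2750 nM

In an in vitro functional assay on cells for agonist activity at Bombesin receptor subtype-3 (Mus musculus), read by luminescence and calcium flux (on this read-out lower numbers stand for an effect already at smaller amounts and higher numbers for an effect only at larger amounts of compound), compound 3 gives 2750 nM and stands highest of the three measured numbers; its nearest neighbour is compound 1 with 31 nM, while compound 2 with 6.2 nM lies furthest away. Compound 4, `O=C(O)c1ccccc1-c1ccc(CCc2ncc(Cc3ccc(Cl)cc3)[nH]2)cc1`, is not yet measured. It differs from compound 3 in one place: 4-chlorobenzyl in place of tert-butyl on an aromatic carbon.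

Within the data shown here, two measured steps bear on this change. The step of an 89-fold higher number from compound 1 to compound 3 (1.95 log units; beyond the scatter) shows what happens when a 3-chlorobenzyl is replaced by tert-butyl at the same aromatic carbon; compound 4 reverses that step with a 4-chlorobenzyl instead. The step of a 440-fold higher number from compound 2 to compound 3 (2.65 log units; beyond the scatter) likewise shows a large rise in the number when a longer group gives way to tert-butyl. Among the measured compounds shown here, a large step downward in this assay is therefore expected for compound 4, a 55-fold lower number from compound 3 to compound 4 (1.74 log units; beyond the scatter), though no measured pair tells how a 4-chlorobenzyl compares with a 3-chlorobenzyl. Compound 4 is estimated at 50 nM, within 12 nM to 220 nM.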

Compound 4, half-maximal effective concentration: 102 nM
The estimate for compound 4 lay 2.0-fold (0.31 log units) below the measured number, within the range that was stated.
By their numbers in this assay, from the lowest: compound 2; then compound 1; then compound 4; then compound 3.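

In this assay, a 4-chlorobenzyl group at this aromatic carbon closes much of the gap left by tert-butyl (a 27-fold lower number from compound 3 to compound 4 (1.43 log units; beyond the scatter)), so the benefit of a chlorobenzyl group over tert-butyl is not confined to 3-chlorobenzyl. Even so, the two chlorobenzyl groups are not interchangeable (a 3.3-fold higher number from compound 1 to compound 4 (0.52 log units; beyond the scatter)), and the 3,3-dimethylbutyl group of compound 2 remains well ahead of 4-chlorobenzyl (a 16-fold higher number from compound 2 to compound 4 (1.22 log units; beyond the scatter)). Nothing available explains these differences. The compounds shown leave open how an unsubstituted benzyl group or a benzyl group carrying fluorine or methoxy would compare with the two chlorobenzyl groups. They also leave open whether a longer chain than 3,3-dimethylbutyl, or a chain ending in an amine, would hold the number of compound 2 at this carbon.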